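The source may hold more compounds than are shown below. What is called first, only, known or untested is meant among the compounds shown, and "the series" means these compounds.

The measured compounds and their values in an assay on RAW264.7 cells for antagonist activity at Toll-like receptor 2 (Mus musculus), read by Griess assay, with a stated time of 24 h; a lower number here means a stronger inhibitor, a higher number a weaker inhibitor:

compound 1, `C=CCSC[C@H](NC(=O)c1cc(OC)c(OC)c(OC)c1)C(=O)OC`: 49300 nM
compound 2, `C#CCSC[C@H](NC(=O)c1cc(OC)c(OC)c(OC)c1)C(=O)OC`: 53200 nM

Compound 2 gives the highest of the two numbers in this assay, and its nearest neighbour is compound 1, whose value is within the scatter of it. The step of a 1.1-fold higher number from compound 1 to compound 2 (0.03 log units; within the scatter) is therefore not a real change; it shows only that exchanging one small unsaturated group for another on the saturated chain carbon bound to a sulfur leaves the read-out where it was.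

Compound 3, `COC(=O)[C@H](CSCc1ccc(F)cc1)NC(=O)c1cc(OC)c(OC)c(OC)c1`, is the compound not yet measured. It differs from compound 2 as follows: 4-fluorophenyl in place of ethynyl on a saturated chain carbon bound to a sulfur. Within the data shown here, the only measured step touches the same place but swaps two small chain groups, so it bears on this change just in showing that the position tolerated a change without effect. Among the measured compounds shown here, no measured compound carries an aromatic ring at this place, so the size of the step is open. Compound 3 is expected to give a number near that of compound 2, with the step of a 1.5-fold lower number from compound 2 to compound 3 (0.18 log units; within the scatter) as the estimate. The estimated value for compound 3 in this assay is 35000 nM, with a range from 9000 nM to 140000 nM.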

Compound 3, half-maximal inhibitory concentration: 28600 nM
Estimate against measurement, compound 3: 1.2-fold (0.09 log units) above; the range from low to high includes it.
By their numbers in this assay, from the lowest: compounds 3, 1 and 2 (each within the scatter of the next).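

Until now, this position had been seen to tolerate only an exchange between two small unsaturated groups, and compound 3 extends that to an aromatic ring: in this assay the change gives a 1.9-fold lower number from compound 2 to compound 3 (0.27 log units; within the scatter) and, set against the vinyl compound, a 1.7-fold lower number from compound 1 to compound 3 (0.24 log units; within the scatter). Even a change as large as 4-fluorophenyl for ethynyl or vinyl therefore leaves all three compounds within the scatter of one another, so none of these groups can be ranked above another, and no trend with the size of the group can be read from them. No measurement of any other kind bears on this result, so the data offer no explanation for it.

The compounds shown do not separate the contribution of the fluorine from that of the ring, as a plain phenyl would be needed to do so, and they do not show whether a group of another kind at this place, such as an amine, a carboxylic acid or a longer chain, would move the number beyond the scatter. They also say nothing about changes elsewhere on the shared core, all of which stays constant across compounds 1, 2 and 3.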